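The source may report more compounds than this note shows. Statements on the series, on what has been measured and on what is new or still open speak of the compounds shown alone.

Measured compounds:
compound 1 `OC[C@H]1O[C@@H](Cc2ccccc2)[C@H](O)[C@@H](OCc2ccccc2)[C@@H]1OCc1ccccc1` with 20200 nM
compound 2 `O[C@@H]1[C@@H](OCc2ccccc2)[C@H](OCc2ccccc2)[C@@H](COCc2ccccc2)O[C@H]1CC1CCCCC1` with 4100 nM

In a functional assay on HL-60 cells (Homo sapiens) for antiproliferative activity, read by MTT assay (on this read-out lower numbers stand for stronger inhibition and higher numbers for weaker inhibition), compound 2 gives the lower of the two numbers, and compound 1, which differs from it in more than one place, gives the higher one. The unmeasured compound 3 `C=CC[C@@H]1O[C@H](COCc2ccccc2)[C@@H](OCc2ccccc2)[C@H](OCc2ccccc2)[C@H]1O` departs from compound 2 by a single change: vinyl in place of cyclohexyl on a saturated chain carbon bound to a saturated ring carbon. For the measured compounds named here, no measured pair shows the effect of this change alone. Since the larger saturated ring gave compound 2 its stronger number than compound 1 shows, the author expects the step of a 2.9-fold higher number from compound 2 to compound 3 (0.47 log units; beyond the scatter) to weaken inhibition beyond the scatter. Compound 3 is therefore estimated at 12000 nM with a range from 5000 nM to 30000 nM.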

Compound 3, half-maximal inhibitory concentration: 15100 nM
For compound 3 the middle estimate is 1.3-fold (0.10 log units) below the measured one; measured number inside the range.
By their numbers in this assay, from the lowest: compound 2; then compounds 3 and 1 (each within the scatter of the next).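

In this assay, vinyl in place of cyclohexyl on a saturated chain carbon bound to a saturated ring carbon gives a 3.7-fold higher number from compound 2 to compound 3 (0.57 log units; beyond the scatter). This single change, which also reads as cyclohexylmethyl to allyl, shows that inhibition at this position responds to the group it carries, with the cyclohexyl compound 2 giving the lower number. Nothing available explains this difference. The compounds shown leave open whether a carbocycle is needed here, and how a longer chain, an amine or a carboxylic acid at this position would read.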